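A few compounds are considered here, and "the series" means these few. Any claim that something is new, unique, unknown or untested is made for them only; others in the source may bear on it.

Values in a functional assay on MDA-MB-231 cells (Homo sapiens) for cytotoxicity, read by MTT assay, with a stated time of 24 h; a higher number here means a weaker inhibitor, a lower number a stronger inhibitor:
compound 1 `CCCCCCCCCCCCCCCCCC(=O)Nc1nnc(S[C@@H]2O[C@H](CO)[C@H](O)[C@H](O)[C@H]2O)s1`: 67100 nM
compound 2 `CCCCCCCCCC(=O)Nc1nnc(S[C@@H]2O[C@H](CO)[C@H](O)[C@H](O)[C@H]2O)s1`: 53100 nM
compound 3 `CCCCCCCC(=O)Nc1nnc(S[C@@H]2O[C@H](CO)[C@H](O)[C@H](O)[C@H]2O)s1`: 30800 nM

Compound 3 cannot be separated from compound 2, with a 1.7-fold lower number from compound 2 to compound 3 (0.24 log units; within the scatter). It does stand apart from compound 1, with a 2.2-fold lower number from compound 1 to compound 3 (0.34 log units; beyond the scatter). The remaining pair shows a 1.3-fold lower number from compound 1 to compound 2 (0.10 log units; within the scatter).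

Compound 4 `CCCCCCCC/C=C\CCCCCCCC(=O)Nc1nnc(S[C@@H]2O[C@H](CO)[C@H](O)[C@H](O)[C@H]2O)s1` differs from compound 3 by dec-1-en-1-yl in place of hydrogen on a saturated chain carbon, seven bonds along the chain from a carbonyl carbon. The closest measured guide is the modest step at the same place, a 2.2-fold lower number from compound 1 to compound 3 (0.34 log units; beyond the scatter), read in reverse. For the measured compounds named here, no measured compound carries a double bond, so that part of the change is untested. The expected step in this assay is a 2.1-fold higher number from compound 3 to compound 4 (0.32 log units; beyond the scatter), a modest rise in the number. The estimated value for compound 4 is 65000 nM, within an expected range of 30000 nM to 130000 nM.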

Compound 4, half-maximal inhibitory concentration: 43600 nM
Compound 4: the middle estimate sits 1.5-fold (0.17 log units) above what was measured; measured number inside the range.
By their numbers in this assay, from the lowest: compounds 3, 4, 2 and 1 (each within the scatter of the next, the first and the last beyond it).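

In this assay the double bond gives no separable shift at this position: dec-1-en-1-yl in place of decyl reads as a 1.5-fold lower number from compound 1 to compound 4 (0.19 log units; within the scatter) and stays within the scatter. Compound 4 also cannot be told from the shorter saturated chains, with a 1.4-fold higher number from compound 3 to compound 4 (0.15 log units; within the scatter) and a 1.2-fold lower number from compound 2 to compound 4 (0.09 log units; within the scatter) both within the scatter, even though compound 1 and compound 3 stand apart from each other. No available measurement explains this result.

Still open, from the compounds shown here alone, is what a shorter chain, or an amine or a carboxylic acid in place of dec-1-en-1-yl, would give here.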